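This account rests on a few compounds, and the source may have more. Where it says the series, first, only, none or still open, it means among the compounds named here.

In a physicochemical assay for solubility, with a stated time of 24 h, tested at 30 mg/mL (a higher number here means a more soluble compound, a lower number a less soluble compound), compound 1 (`Cc1cc(COc2ccc(S(=O)(=O)NCC(=O)NO)cc2)c2ccccc2n1`) gives 100000 nM and compound 2 (`CCN(C1(C(=O)NO)CN(C(=O)C(C)C)C1)S(=O)(=O)c1ccc(OCc2cc(C)nc3ccccc23)cc1`) gives 44000000 nM on the same read-out. Compound 2 therefore holds the higher of the two numbers, and its gap to compound 1 lies beyond the scatter. Compound 3 (`Cc1cc(COc2ccc(S(=O)(=O)N(C(C)C)C3(C(=O)NO)CN(C(=O)C(C)C)C3)cc2)c2ccccc2n1`) differs from compound 2 by one change (methyl in place of hydrogen on a saturated chain carbon bound to a saturated chain carbon and a sulfonamide nitrogen), methyl in place of hydrogen on a saturated chain carbon bound to a saturated chain carbon and a sulfonamide nitrogen, which reads as ethyl to isopropyl. Within the data shown here, no step between measured compounds covers this change, so the expectation starts from compound 2 at 44000000 nM in this assay and assumes no step beyond the scatter, with a slight fall as the likelier direction. The expected size is a 1.5-fold lower number from compound 2 to compound 3 (0.17 log units; within the scatter) on this estimate. For compound 3 the estimated value is 30000000 nM (expected range 9000000 nM to 50000000 nM).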

Compound 3, solubility: 2200000 nM
Compound 3: middle estimate off by 14-fold (1.13 log units), on the high side; measured number below the stated range.
By their numbers in this assay, from the lowest: compound 1; then compound 3; then compound 2.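

In this assay, this place on the chain proves sensitive to a very small change: methyl in place of hydrogen on a saturated chain carbon bound to a saturated chain carbon and a sulfonamide nitrogen, which reads as ethyl to isopropyl, gives a 20-fold lower number from compound 2 to compound 3 (1.30 log units; beyond the scatter) and so lies beyond the scatter. Among these compounds, with only 1 heavy atom entering, this single-place pair is the only reading of the position so far, and the earlier compounds offered no such pair. No supporting measurement bears on the origin of this step.

Open, from the compounds shown here alone, is whether the fall follows from branching or from the added carbon alone, which an unbranched propyl chain at this place would separate from the isopropyl of compound 3. A cyclopropyl group or a chain ending in an amine at the same place also remains to be read.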